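Hydrogen for Methyl on an Aromatic Oxygen: Compound 3 Expected

The source may hold more compounds than are shown below. What is called first, only, known or untested is meant among the compounds shown, and "the series" means these compounds.

Measured compounds:
compound 1 `O=C(Nc1cccc(-n2cc(-c3ccncc3)c(-c3ccc(Cl)c(O)c3)n2)c1)Nc1ccc(Cl)c(Cl)c1` — > 32500 nM
compound 2 `COc1cc(-c2nn(-c3cccc(NC(=O)Nc4ccc(Cl)c(C(F)(F)F)c4)c3)cc2-c2ccncc2)ccc1Cl` — > 32500 nM

In a functional assay on Malme-3M cells (Homo sapiens) for inhibition, read by sulforhodamine B assay, with a stated time of 48 h (on this read-out higher numbers stand for lower toxicity in this test and lower numbers for higher toxicity in this test), compound 2 gives > 32500 nM, which is a limit of the assay and not a number. Compound 1 also stands at a limit, > 32500 nM. Both values shown sit at the same limit (the limit of > 32500 nM in this assay, at which 2 of the 2 values shown sit). Compound 3 `O=C(Nc1cccc(-n2cc(-c3ccncc3)c(-c3ccc(Cl)c(O)c3)n2)c1)Nc1ccc(Cl)c(C(F)(F)F)c1` differs from compound 2 by hydrogen in place of methyl on an oxygen on an aromatic ring. Going by the values given here, no step between measured compounds is known, so the step that the limit leaves unreadable from compound 2 to compound 3 is expected to be none beyond the scatter. Compound 3 is therefore estimated at 40000 nM, between 15000 nM and 100000 nM, most likely reported again only as a limit.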

Compound 3, concentration lethal to 50% of the cells: 9580 nM
Estimate against measurement, compound 3: 4.2-fold (0.62 log units) above; the whole stated range lies above it.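

In this assay compound 3, at 9580 nM, is the only one of the three compounds shown with a value that is not a limit. Methoxy to hydroxy gives an at least 3.3-fold lower number from compound 2 to compound 3 (0.53 log units; beyond the scatter), and trifluoromethyl in place of chloro gives an at least 3.3-fold lower number from compound 1 to compound 3 (0.53 log units; beyond the scatter). Among these compounds, a value below the limit appears only where hydroxy and trifluoromethyl occur together, so the effect of hydrogen in place of methyl on this oxygen can be read only with trifluoromethyl present.

On these data alone, how large the two steps really are stays open: the limit of > 32500 nM in this assay, at which 2 of the 3 values shown sit. Also open is how an amine or an ethoxy group at this place on the ring would read.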